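The source may hold more compounds than are shown below. What is called first, only, known or untested is meant among the compounds shown, and "the series" means these compounds.

Measured in an ADME assay on microsomes from liver (Rattus norvegicus) for metabolic stability, read by LC-MS, with a stated time of 30 min, tested at 1 uM; on this read-out higher numbers stand for a more stable compound and lower numbers for a less stable compound:
- compound 1 `CC(C)(C)NCc1cc(Cl)cc(Nc2nc3cc(F)c(F)cc3n2Cc2ccc(C(F)(F)F)cc2)c1O`: 94%
- compound 2 `CC(C)(C)NCc1cc(Cl)cc(Nc2nc3ccccc3n2Cc2ccc(C(F)(F)F)cc2)c1O`: 9%
- compound 3 `Cc1cc(CNC(C)(C)C)c(O)c(Nc2nc3cc(F)c(F)cc3n2Cc2ccc(C(F)(F)F)cc2)c1`: 89%

Compound 1 stands high on these numbers. Its closest value gives a number 5 percentage points lower from compound 1 to compound 3 (within the scatter), while compound 2 lies far lower at 9%.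

Compound 4 `CCNCc1cc(Cl)cc(Nc2nc3cc(F)c(F)cc3n2Cc2ccc(C(F)(F)F)cc2)c1O` keeps the core of compound 1 and alters one group: ethyl in place of tert-butyl on an amine nitrogen. Among the compounds with values here, no measured step touches that amine. The only one, a number 5 percentage points lower from compound 1 to compound 3 (within the scatter), is methyl in place of chloro on an aromatic carbon, so it offers little guidance. With compound 1 at 94% there is little room to rise, so a fall is more likely than a gain. The expected change is a number 19 percentage points lower from compound 1 to compound 4 (beyond the scatter). For compound 4 the estimate is 75%, with an expected range of 50% to 93%.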

Compound 4, percent of the compound remaining: 98%
The estimate for compound 4 lay 23 percentage points below the measured number; the measured number lies above the stated range.
By their numbers in this assay, from the lowest: compound 2; then compounds 3, 1 and 4 (each within the scatter of the next).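

In this assay, the first change made at this amine nitrogen, ethyl in place of tert-butyl, gives a number 4 percentage points higher from compound 1 to compound 4 (within the scatter) and so leaves the number where it stood. On this core, then, the high reading does not depend on the tert-butyl group, and the smaller ethyl group serves as well. No available evidence explains this result.

Going by these compounds, whether the number would hold with an isopropyl group, a cyclopropyl group or a longer chain such as n-butyl on this nitrogen remains open. On these data alone, a bare primary amine is an equally open case.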